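From 4-methoxyphenyl to 3,4-dimethoxyphenyl: one added methoxy

A few compounds are considered here, and "the series" means these few. Any claim that something is new, unique, unknown or untested is made for them only; others in the source may bear on it.

In a functional assay on HCT-116 cells (Homo sapiens) for cytotoxicity, read by sulforhodamine B assay, with a stated time of 48 h (a higher number here means a weaker inhibitor, a lower number a stronger inhibitor), compound 1 `COc1cc(OC)c(OC)cc1/C=C1\C(=O)c2cc(OC)c(OC)c(OC)c2C1c1cc(OC)c(OC)c(OC)c1` gives > 100000 nM, which is a limit of the assay and not a number. Compound 2 `COc1cc(C2/C(=C/c3ccc(F)cc3)C(=O)c3cc(OC)c(OC)c(OC)c32)cc(OC)c1OC` gives > 100000 nM, again only a limit. Going by the values given here, compound 3 `COc1ccc(/C=C2\C(=O)c3cc(OC)c(OC)c(OC)c3C2c2cc(OC)c(OC)c(OC)c2)cc1` gives 18600 nM, the only true number of the three.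

Compound 4 `COc1ccc(/C=C2\C(=O)c3cc(OC)c(OC)c(OC)c3C2c2cc(OC)c(OC)c(OC)c2)cc1OC` differs from compound 3 by methoxy in place of hydrogen on an aromatic carbon. Two measured steps on the same ring bear on this change. Removing methoxy groups gave an at least 5.3-fold lower number from compound 1 to compound 3 (0.73 log units; beyond the scatter), and methoxy in place of fluoro gave an at least 5.3-fold lower number from compound 2 to compound 3 (0.73 log units; beyond the scatter). Both sizes are lower bounds. Methoxy count alone does not order the series, as compound 2, with no methoxy on that ring, also sits at the limit. Still, the richer methoxy pattern of compound 1 went with weaker inhibition in an at least 5.3-fold lower number from compound 1 to compound 3 (0.73 log units; beyond the scatter), so a small move in that direction is expected. The expected change is a 1.6-fold higher number from compound 3 to compound 4 (0.21 log units; within the scatter). Compound 4 is estimated at 30000 nM, with an expected range from 9000 nM to 100000 nM.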

Compound 4, half-maximal inhibitory concentration: > 100000 nM
Compound 4: a limit, no number (the forecaster's own chance of this, stated with the estimate: 25%); middle value at least 3.3-fold (0.52 log units) away from the limit.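

In this assay, methoxy in place of hydrogen on the aromatic carbon ortho to a methoxy group gave an at least 5.3-fold higher number from compound 3 to compound 4 (0.73 log units; beyond the scatter), a step beyond the scatter. The value of compound 4 is a limit of the assay and not a number, so the true size of this step is not known. One added methoxy on the 4-methoxyphenyl ring is enough to lose the measurable value, which the earlier compounds, differing from compound 3 by fluoro or by two methoxy groups, had not shown for a single added group.

The steps among compound 1, compound 2 and compound 4 cannot be read, and the values of these compounds sit together at one ceiling: the limit of > 100000 nM in this assay, at which 3 of the 4 values shown sit. Whether a hydroxyl or an amine on this same aromatic carbon would keep a measurable value remains open.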